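Removing a Methyl From a Growth Inhibitor

The source may report more compounds than this note shows. Statements on the series, on what has been measured and on what is new or still open speak of the compounds shown alone.

Of the compounds shown here, three sharing one core have been measured in a functional assay on the whole organism for inhibition, with Lepidium sativum as the target, tested at 100 ppm; on this read-out lower numbers stand for less inhibition of growth and higher numbers for more inhibition of growth at the one concentration tested. Compound 1 `CCCCCCC(ON1C(=O)c2ccccc2C1=O)C(=O)OCC` gives 72% in this assay. Compound 2 `CCOC(=O)C(CC)ON1C(=O)c2ccccc2C1=O` gives 94%. Compound 3 `CCOC(=O)C(C)(C)ON1C(=O)c2ccccc2C1=O` gives 95%, the highest of the three numbers, though compound 2 lies within the scatter of it; only compound 1 lies beyond the scatter below it. Among the compounds with values here, the one measured step between compounds differing in a single place is a number 22 percentage points higher from compound 1 to compound 2 (beyond the scatter), hydrogen in place of butyl on a saturated chain carbon, three bonds along the chain from a carbonyl carbon and an oxygen on an unsaturated carbon.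

Compound 4 `CCOC(=O)C(C)ON1C(=O)c2ccccc2C1=O` has not yet been measured. It differs from compound 3 by hydrogen in place of methyl on a saturated chain carbon bound to a carbonyl carbon, an oxygen on an unsaturated carbon and a saturated chain carbon. Like the step from compound 1 to compound 2, this removes carbon from a chain carbon; that earlier step was modest and moved the number upward, but compound 2 and compound 3 already sit together at the top of the numbers, leaving little room above. Compound 4 is therefore expected to show a number 2 percentage points lower from compound 3 to compound 4 (within the scatter), a change no larger than the scatter. The estimate for compound 4 in this assay is 93%, within a range from 80% to 99%.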

Compound 4, percent growth inhibition at one concentration: 100%
Compound 4: the middle estimate sits 7 percentage points below what was measured; measured number outside the range, above it.
By their numbers in this assay, from the lowest: compound 1; then compounds 2, 3 and 4 (each within the scatter of the next).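

Hydrogen in place of methyl on this saturated chain carbon gives a number 5 percentage points higher from compound 3 to compound 4 (within the scatter) in this assay, so the carbon that carries two methyl groups in compound 3 and one in compound 4 shows no difference that can be told from the scatter. The same holds for the other short-chain comparison, a number 6 percentage points higher from compound 2 to compound 4 (within the scatter), which places compound 2, compound 3 and compound 4 together at the top of the read-out whichever of these small substitutions the carbon carries. Within the data shown here, only the long chain stands apart, with a number 28 percentage points higher from compound 1 to compound 4 (beyond the scatter), a second step beyond the scatter that sets compound 1 below the group and adds a comparison with the pentyl change to the one earlier step from that compound.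

Nothing available gives a reason for these numbers. From the compounds shown here alone, it remains open where between these short groups and the chain of compound 1 the numbers begin to fall, as a propyl or butyl group on this carbon could show, and whether a carboxylic acid in place of the ethyl ester would keep the inhibition seen in this assay at this one concentration, where the three top compounds cannot be separated.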